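Ester Swap on a Shared Terpenoid Core: Cytotoxicity Outlook

This account rests on a few compounds, and the source may have more. Where it says the series, first, only, none or still open, it means among the compounds named here.

Measured compounds:
Compound 1, `C=C1[C@H](O)[C@@H](OC(=O)C(C)(C)C)[C@@H](O)C(C)(C)/C=C/[C@H](C)[C@H](OC(=O)c2ccccc2)[C@@]2(O)C[C@@](C)(O)[C@H](OC(C)=O)[C@@H]2[C@H]1OCC(C)C`, gives 31700 nM in a toxicity assay on HEK-293T cells (Homo sapiens) for cytotoxicity, read by MTT assay, with a stated time of 48 h; on this read-out lower numbers stand for stronger inhibition and higher numbers for weaker inhibition.
Compound 2, `C=C1[C@H](O)[C@@H](OC(=O)c2cccc(C)c2)[C@@H](O)C(C)(C)/C=C/[C@H](C)[C@H](OC(=O)c2ccccc2)[C@@]2(O)C[C@@](C)(O)[C@H](OC(C)=O)[C@@H]2[C@H]1OCC(C)C`, gives 31300 nM in this assay.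
Compound 3, `C=C1[C@H](OC(C)=O)[C@@H](OC(C)=O)[C@@H](OC(C)=O)C(C)(C)/C=C/[C@H](C)[C@H](OC(=O)c2ccccc2)[C@@]2(O)C[C@@](C)(OC(=O)C(C)(C)C)[C@H](OC(C)=O)[C@@H]2[C@H]1OCC(C)C`, gives 56300 nM in this assay.

Compound 1 and compound 2 share one core and differ in a single spot: 3-methylphenyl in place of tert-butyl on a carbonyl carbon. This exchange made a step of a 1.0-fold lower number from compound 1 to compound 2 (0.01 log units; within the scatter), so the two values lie within the scatter of each other and no order between them can be read.

Compound 3 carries a different core; how it differs from the core of compound 1 is not broken down here. Its value in this assay is the highest of the three measured numbers, but its distance to compound 1 and to compound 2 stays within the scatter, so nothing more than that is stated.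

Compound 4, `C=C1[C@H](OC(C)=O)[C@@H](OC(C)=O)[C@@H](OC(C)=O)C(C)(C)/C=C/[C@H](C)[C@H](OC(=O)c2ccccc2)[C@@]2(O)C[C@@](C)(OC(=O)c3cccc(C)c3)[C@H](OC(C)=O)[C@@H]2[C@H]1OCC(C)C`, is not yet measured. It is reached from compound 3 by 3-methylphenyl in place of tert-butyl on a carbonyl carbon. The place is described in the same words as for the change from compound 1 to compound 2, so this is the same change applied to the other core.

Because a 1.0-fold lower number from compound 1 to compound 2 (0.01 log units; within the scatter) was within the scatter, the expected step from compound 3 to compound 4 is a 1.0-fold lower number from compound 3 to compound 4 (0.00 log units; within the scatter), resting on that single earlier pair only. Compound 4 is therefore estimated at 56000 nM, with a likely range from 30000 nM to 105000 nM.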

Compound 4, half-maximal inhibitory concentration: 7220 nM
Compound 4: the middle estimate sits 7.8-fold (0.89 log units) above what was measured, outside the stated range (below it).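

In this assay, putting 3-methylphenyl in place of tert-butyl on a carbonyl carbon gave a 7.8-fold lower number from compound 3 to compound 4 (0.89 log units; beyond the scatter), so on the core of compound 3 this exchange brought a real shift, though a modest one. Set beside the earlier pair, the same exchange did not carry over from one core to the other with the same size of step: the same change on two cores in this assay, a 1.0-fold lower number (0.01 log units; within the scatter) from compound 1 to compound 2 and a 7.8-fold lower number (0.89 log units; beyond the scatter) from compound 3 to compound 4, 7.7-fold (0.89 log units) apart, beyond the scatter of two such steps. This shows that, in these two pairs, the outcome of the exchange depends on the core that carries it, but it does not show which part of the core is responsible or why, and two pairs give no rule for predicting the step on any further core in the series.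

The compounds shown leave open whether other groups on the same carbonyl carbon, such as a longer alkyl chain or a phenyl ring carrying an amine, would follow the step seen on the core of compound 3 or the absence of a readable step seen on the core of compound 1. They also leave open whether the gap between the two cores would appear in any read-out other than this assay.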